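A few compounds are considered here, and "the series" means these few. Any claim that something is new, unique, unknown or untested is made for them only; others in the source may bear on it.

Compound 1 `Cn1ncnc1-c1ccccc1NCC1=NCCN1` — 63.1 nM
Compound 2 `CCCn1ncnc1-c1ccccc1NCC1=NCCN1` — 251 nM

In an in vitro functional assay on cells (Fibroblast) for agonist activity at Alpha-1D adrenergic receptor (Homo sapiens) (on this read-out lower numbers stand for an effect already at smaller amounts and higher numbers for an effect only at larger amounts of compound), compound 2 has the highest number of the two measured here; its nearest neighbour is compound 1, and the step of a 4.0-fold higher number from compound 1 to compound 2 (0.60 log units; beyond the scatter) lies beyond the usual scatter. Compound 3 `CCCCn1ncnc1-c1ccccc1NCC1=NCCN1` is the next member of the same series, and it differs from compound 2 by methyl in place of hydrogen on a saturated chain carbon, three bonds along the chain from an aromatic nitrogen — read one bond further out, the change is propyl to butyl on the aromatic nitrogen. Among the measured compounds shown here, the only measured step that bears on this change is a 4.0-fold higher number from compound 1 to compound 2 (0.60 log units; beyond the scatter), where lengthening the same chain gave a higher number. For compound 3 the expected step is therefore a 1.8-fold higher number from compound 2 to compound 3 (0.25 log units; within the scatter), a more modest rise than before. The estimate for compound 3 in this assay is 450 nM, with a range from 150 nM to 1300 nM.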

Compound 3, half-maximal effective concentration: 398 nM
Compound 3: the middle estimate sits 1.1-fold (0.05 log units) above what was measured; the range from low to high includes it.
By their numbers in this assay, from the lowest: compound 1; then compounds 2 and 3 (each within the scatter of the next).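

In this assay, the methyl that turns propyl into butyl, on a saturated chain carbon three bonds along the chain from an aromatic nitrogen, gives a 1.6-fold higher number from compound 2 to compound 3 (0.20 log units; within the scatter), so compounds 2 and 3 cannot be told apart here. Set against the methyl group of compound 1, the butyl chain shows a 6.3-fold higher number from compound 1 to compound 3 (0.80 log units; beyond the scatter), so the separation from compound 1 seen with propyl is also seen with butyl. No evidence is available that would explain these numbers.

The compounds shown do not tell whether a longer chain, such as pentyl, would stay level with compounds 2 and 3 or move away from them. They also leave open how ethyl on the aromatic nitrogen would compare, and what a chain ending in an amine or a carboxylic acid would give.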